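The compounds below may be only part of what the source reports. "The series", "measured", "known", "first", "only" and "open" are said of these compounds alone.

Compound 1 `CCCS(=O)(=O)Nc1cccc2c1CCC2c1ncc[nH]1` gives in a functional assay on CHO cells for agonist activity at Alpha-1B adrenergic receptor (Homo sapiens), read by FLIPR and calcium flux (on this read-out higher numbers stand for an effect only at larger amounts of compound and lower numbers for an effect already at smaller amounts), a value of > 10000 nM, which is a limit of the assay and not a number.
Compound 2 `c1cc(-c2nccs2)c2c(c1)C(c1ncc[nH]1)CC2` gives in this assay > 10000 nM, likewise a limit.
Compound 3 `c1cc(-c2cn[nH]c2)c2c(c1)C(c1ncc[nH]1)CC2` gives in this assay > 10000 nM, again a limit.

Compound 3 thus stands where every measured compound stands: at the limit of > 10000 nM in this assay, at which 3 of the 3 values shown sit, so no number separates it from compound 1 or compound 2. The steps that connect the three, a step that the two limits leave unreadable from compound 1 to compound 2, a step that the two limits leave unreadable from compound 1 to compound 3 and a step that the two limits leave unreadable from compound 2 to compound 3, cannot be read in size, as both ends of each are limits. Compound 4 `Cn1cc(-c2cccc3c2CCC3c2ncc[nH]2)cn1` differs from compound 3 by methyl in place of hydrogen on an aromatic nitrogen. For the measured compounds named here, none of the measured steps touches the aromatic nitrogen, so none bears on this change; the three only show that exchanging the aromatic substituent among three groups left every compound at the limit. Compound 4 is therefore expected to stay near that limit, with a step that the limit leaves unreadable from compound 3 to compound 4 expected to be none beyond the scatter. In this assay compound 4 is estimated at 15000 nM, in a range from 4000 nM to 60000 nM.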

Compound 4, half-maximal effective concentration: > 10000 nM
Compound 4: a limit, no number; the forecaster's own chance of this, stated with the estimate: 85%; the middle value lies beyond the limit too.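

Compound 4 sits at the same limit as compound 1, compound 2 and compound 3, so no step among the four can be read in size: the limit of > 10000 nM in this assay, at which 4 of the 4 values shown sit.

The compounds shown leave open whether methyl in place of hydrogen on an aromatic nitrogen, or any exchange of the aromatic substituent, changes the read-out in this assay at all.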